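Swapping 4-ethylphenyl for pyridin-2-yl in a cytotoxicity series

The source may report more compounds than this note shows. Statements on the series, on what has been measured and on what is new or still open speak of the compounds shown alone.

Measured so far in a functional assay on PANC-1 cells (Homo sapiens) for cytotoxicity, read by MTT assay, with a stated time of 72 h; on this read-out higher numbers stand for weaker inhibition and lower numbers for stronger inhibition:
- Compound 1 `O=C1C(Nc2ccc(-c3ccc(Cl)cc3)cc2)=CC(=O)c2ncncc21`: 4400 nM
- Compound 2 `CCc1ccc(-c2ccc(NC3=CC(=O)c4ncncc4C3=O)cc2)cc1`: 2300 nM

Among the measured compounds shown here, only two compounds have numbers so far, and compound 2 cannot be separated from the other one, since the gap between them is no larger than repeat measurements would give. The next compound, compound 3 `O=C1C(Nc2ccc(-c3ccccn3)cc2)=CC(=O)c2ncncc21`, carries pyridin-2-yl in place of 4-ethylphenyl on an aromatic carbon, para to a large group: pyridin-2-yl in place of 4-ethylphenyl on an aromatic carbon.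

For the measured compounds named here, this is a bigger exchange than the single measured step, in which ethyl replaced chloro and the ring carrying it stayed. Going by the values given here, a whole ring is replaced here, and no measured pair covers such a change, so the guidance is weak. Among the compounds with values here, the one step available is a 1.9-fold lower number from compound 1 to compound 2 (0.28 log units; within the scatter). Resting on that small step, no change beyond the scatter is expected in this assay, and the range is kept wide. The expected step is a 1.4-fold higher number from compound 2 to compound 3 (0.14 log units; within the scatter). Compound 3 is estimated at 3200 nM, with an expected range of 1100 nM to 9500 nM.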

Compound 3, half-maximal inhibitory concentration: 800 nM
Beside the measured number, compound 3's estimate is 4.0-fold (0.60 log units) above it; the whole stated range lies above it.
By their numbers in this assay, from the lowest: compound 3; then compounds 2 and 1 (each within the scatter of the next).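

In this assay, the group on the aromatic carbon para to a large group does matter: putting pyridin-2-yl in place of 4-ethylphenyl gives a 2.9-fold lower number from compound 2 to compound 3 (0.46 log units; beyond the scatter), and putting it in place of 4-chlorophenyl gives a 5.5-fold lower number from compound 1 to compound 3 (0.74 log units; beyond the scatter). Both steps are modest but lie beyond the scatter, so compound 3 is the strongest inhibitor of the three, whereas the earlier exchange of chloro for ethyl on the outer ring, a 1.9-fold lower number from compound 1 to compound 2 (0.28 log units; within the scatter), stayed within the scatter and showed no clear effect of this position. Nothing measured here explains why the pyridin-2-yl compound gives the lower number.

This exchange alters two things at once: the outer ring gains a nitrogen and a hydrogen-bond acceptor, and it loses the ethyl or chloro substituent, so the compounds shown cannot say which of these changes goes with the lower number. A plain phenyl ring at this place would help to separate the two, while pyridin-3-yl or pyridin-4-yl would show whether the location of the ring nitrogen matters.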